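Tert-Butyl for Ethyl on the Ester Aryl: Tolerability Outlook

The compounds below may be only part of what the source reports. "The series", "measured", "known", "first", "only" and "open" are said of these compounds alone.

Compound 1 `Fc1ccc(-c2cn(-c3ccnc4cc(Cl)ccc34)nn2)cc1`: in an ADME assay on HepG2 cells (Homo sapiens) for cytotoxicity, read by MTT assay, with a stated time of 24 h (a lower number here means that less compound is tolerated, a higher number that more compound is tolerated), compound 1 gives > 3080000 nM, a limit.
Compound 2 `OCCCc1cn(-c2ccnc3cc(Cl)ccc23)nn1`: in this assay compound 2 gives 151000 nM.
Compound 3 `CCc1ccc(C(=O)OCCCc2cn(-c3ccnc4cc(Cl)ccc34)nn2)cc1`: in this assay compound 3 gives > 2550000 nM, a limit.

Compound 2 is the only one of the three with a number; compound 1 and compound 3 stand at limits. The step of an at least 20-fold lower number from compound 1 to compound 2 (1.30 log units; beyond the scatter) was large, and the step of an at least 16-fold higher number from compound 2 to compound 3 (1.22 log units; beyond the scatter) returned the series to a limit. Compound 3 sits at the limit of > 2550000 nM in this assay, at which 1 of the 3 values shown sits, while compound 1 sits at the limit of > 3080000 nM in this assay, at which 1 of the 3 values shown sits.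

Compound 4 `CC(C)(C)c1ccc(C(=O)OCCCc2cn(-c3ccnc4cc(Cl)ccc34)nn2)cc1` differs from compound 3 by tert-butyl in place of ethyl on an aromatic carbon. Neither measured step bears directly on this change: one replaced the aryl on the triazole with a hydroxypropyl chain, the other capped that hydroxyl as the ester. Going by the values given here, no measured step varies the substituent on the ester aryl, so no step beyond the scatter is expected in this assay. Compound 4 is therefore expected to remain at a limit, around 2500000 nM, within 800000 nM to 5000000 nM. The expected step is an at least 1.0-fold lower number from compound 3 to compound 4 (0.00 log units; that floor lies within the scatter).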

Compound 4, half-maximal cytotoxic concentration: > 2230000 nM
Compound 4: a limit, no number; the forecaster's own chance of this, stated with the estimate: 75%; the middle value lies beyond the limit too.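

In this assay, compound 3 and compound 4 both stand at limits rather than numbers, so the step between them cannot be read. The compounds shown leave open whether tert-butyl in place of ethyl on an aromatic carbon changes the tolerated concentration at all.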